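This account rests on a few compounds, and the source may have more. Where it says the series, first, only, none or still open, it means among the compounds named here.

The study is concerned with a small set of compounds sharing one core, tested in a functional assay on the whole organism (strain Sprague-Dawley CD) for inhibition, with Rattus norvegicus as the target, read by paw edema, at a dose of 30 mg/kg by the intraperitoneal route; on this read-out higher numbers stand for a stronger effect at the one dose given and lower numbers for a weaker effect. Compound 1, `CCOC(=O)C(=O)Nc1cccccc1=O`, gives 84% in this assay. Compound 2, `CCOC(=O)C(=O)Nc1ccccc(O)c1=O`, gives 61%, and compound 3, `CCOC(=O)C(=O)Nc1ccccc(NC)c1=O`, gives 83%. Among the three numbers compound 3 stands second highest, sitting within the scatter of compound 1 and well above compound 2. The measured steps are a number 23 percentage points lower from compound 1 to compound 2 (beyond the scatter), a number 1 percentage points lower from compound 1 to compound 3 (within the scatter) and a number 22 percentage points higher from compound 2 to compound 3 (beyond the scatter).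

Compound 4 is `CCOC(=O)C(=O)Nc1ccccc(N(C)C(=O)C(=O)OCC)c1=O`. Compared with compound 3 it carries (ethoxycarbonyl)carbonyl in place of hydrogen on a nitrogen on an aromatic ring. Among the measured compounds shown here, none of the measured steps touches this nitrogen; the steps that exist only exchange the group on the aromatic carbon. For the measured compounds named here, the one step that leaves the methylamino nitrogen bearing hydrogen, the step from compound 1 to compound 3, lies within the scatter, so no direction can be read from it for the new substitution. Going by the values given here, with no comparable step available, a modest lowering or no step beyond the scatter is the most that can be anticipated. Compound 4 is therefore expected to give about 72% in this assay, within a range from 48% to 90%. This estimate corresponds to an expected a number 11 percentage points lower from compound 3 to compound 4 (beyond the scatter).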

Compound 4, a percentage reported as inhibition, in the whole organism at one dose (the size of the read-out at that dose, not a potency): 51%
For compound 4 the middle estimate is 21 percentage points above the measured one, and the stated range covers the measured number.
By their numbers in this assay, from the lowest: compounds 4 and 2 (each within the scatter of the next); then compounds 3 and 1 (each within the scatter of the next).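

Among the compounds shown here, this is the first substitution on the methylamino nitrogen, and in this assay (ethoxycarbonyl)carbonyl in place of hydrogen on that nitrogen gives a number 32 percentage points lower from compound 3 to compound 4 (beyond the scatter) as its result. The earlier step that introduced methylamino on an aromatic carbon was a number 1 percentage points lower from compound 1 to compound 3 (within the scatter) and so gave no sign that this position would respond, whereas the new step shows that the nitrogen is not indifferent to what it carries. No measurement shown bears on why the number falls with this substitution.

The compounds shown leave open whether the fall follows from the whole (ethoxycarbonyl)carbonyl group or simply from replacing the hydrogen on this nitrogen. An acetyl group or a second methyl group on the same nitrogen would separate these two readings, and a carboxylic acid in place of the ethyl ester would test the ester end of the group.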